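A few compounds are considered here, and "the series" means these few. Any claim that something is new, unique, unknown or untested is made for them only; others in the source may bear on it.

Measured compounds:
- compound 1, `Cc1cc(Oc2ccc(/C=N/NC(=S)Nc3ccc(F)cc3)cc2)ccc1Cl`, in a physicochemical assay for lipophilicity, in phosphate buffer, measured as octanol-water partition, with a stated time of 24 h (on this read-out higher numbers stand for higher lipophilicity and lower numbers for lower lipophilicity), compound 1 gives 6.07
- compound 2, `Fc1ccc(NC(=S)N/N=C/c2ccc(Oc3ccc(F)cc3)cc2)cc1`, compound 2 gives 5.19
- compound 3, `Cc1cc(Oc2ccc(/C=N/NC(=S)Nc3ccc(Br)cc3)cc2)ccc1Cl`, compound 3 gives 7.89

The three measured compounds share a thiosemicarbazone core and differ at two places. Compound 1 and compound 2 differ on the oxygen on an aromatic ring: 4-fluorophenyl in place of 4-chloro-3-methylphenyl on an oxygen on an aromatic ring. That change brings the value a number 0.88 log units lower from compound 1 to compound 2 (beyond the scatter), and compound 2 stands lowest of the three, with compound 1 nearest and compound 3 furthest from it, both beyond the scatter. Compound 1 and compound 3 differ at an aromatic carbon: bromo in place of fluoro on an aromatic carbon. That single change brings the value a number 1.82 log units higher from compound 1 to compound 3 (beyond the scatter).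

Compound 4, `Fc1ccc(NC(=S)N/N=C/c2ccc(Oc3ccc(Br)cc3)cc2)cc1`, is not yet measured in this assay. It is related to compound 2 by bromo in place of fluoro on an aromatic carbon. This is the same change as from compound 1 to compound 3: the place reads the same, on an aromatic carbon of a six-membered aromatic ring of carbon only, para to a large group, though cut one bond further out the change from compound 2 to compound 4 reads 4-fluorophenoxy to 4-bromophenoxy, whereas from compound 1 to compound 3 it reads (4-fluorophenyl)amino to (4-bromophenyl)amino. Among the measured compounds shown here, with only one measured example of this change, and that one on a different arm of the core, compound 4 is expected to rise from compound 2 by a number 1.51 log units higher from compound 2 to compound 4 (beyond the scatter), somewhat less than the step seen from compound 1 to compound 3, because a number 1.82 log units higher from compound 1 to compound 3 (beyond the scatter) is a single, large observation. Compound 4 is therefore estimated at 6.7, between 5.9 and 7.4.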

Compound 4, partition coefficient: 5.88
Compound 4: the middle estimate sits 0.82 log units above what was measured; measured number below the stated range.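

In this assay, bromo in place of fluoro on an aromatic carbon moves the number in the same direction on the other arm of the shared core, a number 0.69 log units higher from compound 2 to compound 4 (beyond the scatter), so the direction of the change carried over, while the modest size of this step did not reproduce the large one, a number 1.82 log units higher from compound 1 to compound 3 (beyond the scatter). The other new step, a number 0.19 log units lower from compound 1 to compound 4 (within the scatter), exchanges 4-chloro-3-methylphenyl for 4-bromophenyl on the oxygen and does not set the two compounds apart on this read-out. Among the compounds shown here, with only two examples of the bromo change, which differ both in the arm carrying it and in what stands on the opposite arm, the series does not show which of these differences goes with the smaller step, and nothing measured here bears on why the two steps differ in size.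

The compounds shown leave open whether the same step would appear a third time on another pairing of the two arms, which would show how far its size can be relied on. They also leave open how a quite different group, such as an amine or a carboxylic acid, would behave on that same aromatic carbon in either arm.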